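The compounds below may be only part of what the source reports. "The series", "measured", "known", "first", "only" and "open" are said of these compounds alone.

Compound 1 `CC(C)n1ncc2c(C(=O)Nc3ccccc3F)cc(-c3cccnc3)nc21`: 50000 nM
Compound 2 `CC(C)n1ncc2c(C(=O)Nc3ccccc3F)cc(-c3cncs3)nc21`: 100000 nM

Among the compounds with values here, in an ADME assay on LLC-MK2 cells (Macaca mulatta) for cytotoxicity, read by spectrophotometry and crystal violet staining, with a stated time of 4 days (on this read-out higher numbers stand for lower toxicity in this test and lower numbers for higher toxicity in this test), compound 2 gives 100000 nM and compound 1 gives 50000 nM, so compound 2 stands within the scatter of the only other measured compound. The next compound, compound 3 `CC(C)n1ncc2c(C(=O)Nc3ccccc3F)cc(-c3ccncc3)nc21`, carries pyridin-4-yl in place of 1,3-thiazol-5-yl on an aromatic carbon. Within the data shown here, only one measured step bears on this change: a 2.0-fold higher number from compound 1 to compound 2 (0.30 log units; within the scatter), where a pyridin-3-yl group gave way to 1,3-thiazol-5-yl on an aromatic carbon. That single exchange between ring substituents did not move this assay beyond the scatter, so no step beyond the scatter is expected here either. The expected change is a 1.7-fold lower number from compound 2 to compound 3 (0.22 log units; within the scatter), which would stay within the usual scatter. For compound 3 the estimated value is 60000 nM, with an expected range from 25000 nM to 120000 nM.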

Compound 3, half-maximal cytotoxic concentration: 45000 nM
Estimate against measurement, compound 3: 1.3-fold (0.12 log units) above, within the range that was stated.
By their numbers in this assay, from the lowest: compounds 3, 1 and 2 (each within the scatter of the next, the first and the last beyond it).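

In this assay, within the data shown here, pyridin-4-yl in place of 1,3-thiazol-5-yl on this aromatic carbon, next to the ring nitrogen, gives a 2.2-fold lower number from compound 2 to compound 3 (0.35 log units; beyond the scatter), the first step to pass beyond the scatter, though only modestly. Pyridin-4-yl in place of pyridin-3-yl at the same carbon gives a 1.1-fold lower number from compound 1 to compound 3 (0.05 log units; within the scatter), so the two pyridinyl groups cannot be told apart in this assay, and the 1,3-thiazol-5-yl compound separates from only one of them. Nothing available accounts for this small separation.

Going by these compounds, all three compounds share the rest of their structure, so the effect of changes elsewhere on the core remains open. Also open, on these data alone, is how this assay would read with a group of another kind on this carbon, such as an amine or a carboxylic acid.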